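The compounds below may be only part of what the source reports. "The series", "measured", "known", "first", "only" and "open" are said of these compounds alone.

Measured compounds:
compound 1, `CCCc1ccc2nc(N)sc2c1`, gives 6 mg/kg
compound 2, `N=c1sc2cc(OC(F)(F)F)ccc2n1CC(=O)O`, gives > 10 mg/kg

In a functional assay on the whole organism with Rattus norvegicus as the target (on this read-out higher numbers stand for an effect only at larger amounts of compound and lower numbers for an effect already at smaller amounts), compound 1 gives 6 mg/kg. For compound 2 the same read-out yields only a limit, > 10 mg/kg, not a number. From the compounds shown here alone, compound 2 thus sits at the limit of > 10 mg/kg in this assay, at which 1 of the 2 values shown sits, so its true dose is unknown beyond that boundary. Within the data shown here, no step between two measured compounds is available here, and the two values shown cannot be compared as numbers.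

Compound 3, `N=c1sc2cc(OC(F)(F)F)ccc2n1CCN1CCCCC1`, differs from compound 2 by (piperidin-1-yl)methyl in place of carboxy on a saturated chain carbon bound to an aromatic nitrogen. Among the measured compounds shown here, with no measured step to lean on, the author expects the change from compound 2 to compound 3 to reach an at least 1.2-fold lower number from compound 2 to compound 3 (0.09 log units; that floor lies within the scatter), a step toward effects at smaller amounts that may or may not exceed the usual scatter. Compound 3 is therefore estimated to give about 8 mg/kg in this assay, with a range from 2 mg/kg to 30 mg/kg, and a real chance that only a limit is reported again.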

Compound 3, dose for half-maximal effect: 2 mg/kg
Estimate against measurement, compound 3: 4.0-fold (0.60 log units) above; low and high end bracket the measured number.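

In this assay, among these compounds, putting (piperidin-1-yl)methyl in place of carboxy on a saturated chain carbon bound to an aromatic nitrogen gives an at least 5.0-fold lower number from compound 2 to compound 3 (0.69 log units; beyond the scatter) and so provides the first readable step. With the shared core unchanged, this shows that the group carried at this place can shift the dose needed for half-maximal effect in the whole animal by more than the usual scatter. From the compounds shown here alone, the true size of the step remains unknown, and it can be stated only as a minimum because compound 2 has a limit and not a number: the limit of > 10 mg/kg in this assay, at which 1 of the 3 values shown sits.

The compounds shown cannot separate the contribution of the piperidine ring from that of the removal of carboxy. Going by these compounds, whether an open-chain diethylamino group, a morpholine ring or a longer chain in this place would give a similar result remains open.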